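This account rests on a few compounds, and the source may have more. Where it says the series, first, only, none or still open, it means among the compounds named here.

Compound 1 `N#C/C(=C\c1c[nH]c2ccccc12)C(=O)c1c[nH]c2ccccc12` gives only a limit, > 50000 nM. Compound 2 `COc1ccc2c(C(=O)/C(C#N)=C/c3cn(Cc4ccc(Cl)cc4)c4ccccc34)c[nH]c2c1` likewise gives only a limit, > 50000 nM. Compound 3 `COc1ccc2c(C(=O)/C(C#N)=C/c3c[nH]c4ccccc34)c[nH]c2c1` gives 12000 nM.

In a functional assay on PC-3 cells (Homo sapiens) for cytotoxicity, read by WST assay, with a stated time of 48 h (a lower number here means a stronger inhibitor, a higher number a weaker inhibitor), compound 3 is the only one of the three with a measured number; the other two sit at the limit described by the limit of > 50000 nM in this assay, at which 2 of the 3 values shown sit. The step of an at least 4.1-fold higher number from compound 3 to compound 1 (0.61 log units; beyond the scatter) goes with the change (hydrogen in place of methoxy on an aromatic carbon). The step of an at least 4.1-fold lower number from compound 2 to compound 3 (0.61 log units; beyond the scatter) goes with the difference between the two cores, (4-chlorobenzyl in place of hydrogen on an aromatic nitrogen). Compound 4 `N#C/C(=C\c1cn(Cc2ccc(Cl)cc2)c2ccccc12)C(=O)c1c[nH]c2ccccc12` differs from compound 2 by hydrogen in place of methoxy on an aromatic carbon, the same change that was made from compound 3 to compound 1. Since compound 2 already sits at the limit > 50000 nM and the same change weakened compound 3 in an at least 4.1-fold higher number from compound 3 to compound 1 (0.61 log units; beyond the scatter), compound 4 is expected to remain at the limit, with an estimated step that the limit leaves unreadable from compound 2 to compound 4 beside that earlier one. Compound 4 is therefore estimated at 150000 nM, within 50000 nM to 600000 nM.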

Compound 4, half-maximal inhibitory concentration: > 50000 nM
Compound 4: no number, only a limit (the forecaster's own chance of this, stated with the estimate: 90%); the middle value lies beyond the limit too.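

Compound 4 gives only a limit, so the steps to it from compound 2 and from compound 1 cannot be read: the limit of > 50000 nM in this assay, at which 3 of the 4 values shown sit.

The compounds shown leave open whether hydrogen in place of methoxy changes anything when 4-chlorobenzyl sits on the aromatic nitrogen.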